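Phenyl to Methyl on the Pyrazole-Free Core of Compound 2

The source may hold more compounds than are shown below. What is called first, only, known or untested is meant among the compounds shown, and "the series" means these compounds.

The measured compounds:
Compound 1 `C=C(C)C(=O)c1ccc(OC)cc1OC`, 32.3%
Compound 2 `CCOC(=O)c1nn(-c2ccccc2)c(-c2ccc(OC)cc2OC)c1-c1ccccc1`, 20.2%

In a functional assay on the whole organism (strain albino) for inhibition, with Rattus norvegicus as the target, read by paw edema, with stated times of 30 min and 4 h, at a dose of 25 mg/kg by the intraperitoneal route (a lower number here means less inhibition, a higher number more inhibition at the dose given (going by the name of the read-out)), compound 2 gives 20.2%, the lower of the two numbers; compound 1 gives 32.3%, a difference beyond the scatter. Compound 3 `CCOC(=O)c1nn(-c2ccccc2)c(-c2ccc(OC)cc2OC)c1C` differs from compound 2 by methyl in place of phenyl on an aromatic carbon. Going by the values given here, no step of this kind has been measured here, so only a rough expectation is possible. The change is expected to move this assay little, at most modestly, and the step of a number 1.8 percentage points higher from compound 2 to compound 3 (within the scatter) is estimated to stay near or within the scatter. Compound 3 is therefore expected to give about 22%, in the range 8% to 38%.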

Compound 3, a percentage reported as inhibition, in the whole organism at one dose (the size of the read-out at that dose, not a potency): 5.77%
Compound 3: middle estimate off by 16.2 percentage points, on the high side; measured number below the stated range.
By their numbers in this assay, from the lowest: compound 3; then compound 2; then compound 1.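

In this assay, methyl in place of phenyl on this aromatic carbon gives a number 14.4 percentage points lower from compound 2 to compound 3 (beyond the scatter), so this position is not indifferent to the change. In this single pair, the phenyl group goes with the higher inhibition at the dose given. Nothing shown here gives a reason for this step.

Going by these compounds, whether a benzyl group, an ethyl chain or an amine on this carbon would keep or lose the inhibition remains open. So does the effect of a carboxylic acid in place of the ethoxycarbonyl group.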